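A Methyl on the Piperidine Ring, Twice Over

This account rests on a few compounds, and the source may have more. Where it says the series, first, only, none or still open, it means among the compounds named here.

Of the compounds shown here, three have been measured in a functional assay on A549 cells (Homo sapiens) for cytotoxicity, read by MTT assay, with a stated time of 72 h; on this read-out higher numbers stand for weaker inhibition and lower numbers for stronger inhibition. Compound 1 `COc1cc2c(Oc3ccc(NC(=O)c4nnn(-c5ccccc5)c4C)cc3F)ccnc2cc1OCCCN1CCCCC1` gives 100 nM in this assay. Compound 3 `COc1cc2c(Oc3ccc(NC(=O)c4nnn(-c5ccccc5)c4C)cc3F)ccnc2cc1OCCCN1CCC(C)CC1` differs from it by one change, (methyl in place of hydrogen on a saturated ring carbon), and gives 110 nM in this assay; the step of a 1.1-fold higher number from compound 1 to compound 3 (0.04 log units; within the scatter) is small. Compound 2 `COc1cc2c(Oc3ccc(NC(=O)c4nnn(-c5ccc(F)cc5)c4C(F)(F)F)cc3F)ccnc2cc1OCCCN1CCCCC1` has a different core, and the difference between the two cores is not broken down here; in this assay compound 2 gives 110 nM, level with compound 3 and within the scatter of compound 1.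

The unmeasured compound 4 `COc1cc2c(Oc3ccc(NC(=O)c4nnn(-c5ccc(F)cc5)c4C(F)(F)F)cc3F)ccnc2cc1OCCCN1CCC(C)CC1` is compound 2 carrying the same change, (methyl in place of hydrogen on a saturated ring carbon), at a place described in the same words as before. Among the compounds with values here, because the only measured example of this change, a 1.1-fold higher number from compound 1 to compound 3 (0.04 log units; within the scatter), stays within the scatter, compound 4 is expected to sit close to compound 2. The step of a 1.1-fold higher number from compound 2 to compound 4 (0.04 log units; within the scatter) is therefore expected to be small. Compound 4 is estimated to give 120 nM in this assay, with a plausible range from 60 nM to 240 nM.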

Compound 4, half-maximal inhibitory concentration: 120 nM
Estimate against measurement, compound 4: no gap at the digits printed; low and high end bracket the measured number.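

On the core of compound 2, swapping piperidin-1-yl for 4-methylpiperidin-1-yl gives a 1.1-fold higher number from compound 2 to compound 4 (0.04 log units; within the scatter) in this assay. Set side by side, the two steps agree: the same change on two cores in this assay, a 1.1-fold higher number (0.04 log units; within the scatter) from compound 1 to compound 3 and a 1.1-fold higher number (0.04 log units; within the scatter) from compound 2 to compound 4, 1.0-fold (0.00 log units) apart, within the scatter of two such steps. This shows that, on these two cores, the added methyl leaves the read-out within the usual scatter, so the small step seen on the first core also held on the second; it does not show that the same would hold on any further core, and two pairs in one cell assay are too few to support a general rule.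

What the compounds shown leave open is whether the same ring carbon would tolerate something other than methyl, such as an ethyl group, an amine or a carboxylic acid. They also leave open how the read-out would respond to a longer chain in place of the methyl, and whether any such group would travel between the two cores as quietly as the methyl does.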